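The source may report more compounds than this note shows. Statements on the series, on what has been measured and on what is new or still open speak of the compounds shown alone.

Measured compounds:
compound 1, `CC(C)(C)c1ccc(Oc2ccc3c(NCCCNCc4ccco4)ccnc3c2)cc1`, which in an ADME assay for permeability, using PAMPA, with a stated time of 30 min, at pH 7.4 (on this read-out higher numbers stand for higher permeability and lower numbers for lower permeability), gives 317 10^-6 cm/s
compound 2, `COc1ccc(F)cc1CNCCCNc1ccnc2cc(Oc3ccc(C(C)(C)C)cc3)ccc12`, which in this assay gives 317 10^-6 cm/s

Compound 1 stands level with compound 2 at the digits shown; the step of no change at the digits printed from compound 1 to compound 2 (within the scatter) lies within the scatter, so the two values show no difference in this assay.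

Compound 3, `COc1ccc(Oc2ccc3c(NCCCNCc4ccco4)ccnc3c2)cc1`, differs from compound 1 by methoxy in place of tert-butyl on an aromatic carbon. Among the compounds with values here, the one measured step, no change at the digits printed from compound 1 to compound 2 (within the scatter), changes the group on the saturated chain carbon bound to the amine nitrogen, not the aromatic carbon altered here, so no measured step bears directly on this change. With only compound 1 and compound 2 to go on, and both giving the same reading, the expectation for compound 3 in this assay is a step of a 1.1-fold lower number from compound 1 to compound 3 (0.02 log units; within the scatter) that does not exceed the scatter. Compound 3 is therefore estimated at 300 10^-6 cm/s, with a range from 150 10^-6 cm/s to 600 10^-6 cm/s.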

Compound 3, apparent permeability: 317 10^-6 cm/s
Beside the measured number, compound 3's estimate is 1.1-fold (0.02 log units) below it, and the stated range covers the measured number.
By their numbers in this assay, from the lowest: compounds 1, 2 and 3 (each within the scatter of the next).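

In this assay, the aromatic carbon para to a large group now has a measured change: going from 4-(tert-butyl)phenyl to 4-methoxyphenyl gives no change at the digits printed from compound 1 to compound 3 (within the scatter). The earlier pair varied only the group on the saturated chain carbon bound to the amine nitrogen, whereas this exchange replaces a group of 4 heavy atoms and no hydrogen-bond acceptor with one of 2 heavy atoms and 1 hydrogen-bond acceptor, so a second place has been changed with no difference beyond the scatter. Nothing available accounts for this result.

All three compounds share one reading, so they do not show what kind of change at either place would produce a step beyond the scatter. As far as these compounds go, whether a carboxylic acid or an amine on that aromatic carbon, or a longer chain in the linker, would move the number in this assay remains open.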